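A few compounds are considered here, and "the series" means these few. Any claim that something is new, unique, unknown or untested is made for them only; others in the source may bear on it.

Compound 1 `Cc1csc(CN[C@@H]2C[C@H]3C[C@@H]([C@H]2C)C3(C)C)c1`: 12500 nM
Compound 2 `C[C@H]1[C@H](NCc2cc(-c3ccsc3)cs2)C[C@H]2C[C@@H]1C2(C)C`: 25000 nM
Compound 3 `C[C@H]1[C@H](NCc2cc(C3CCCCC3)cs2)C[C@H]2C[C@@H]1C2(C)C`: 780 nM

These three compounds share one core and differ only in the group carried on an aromatic carbon. In an ADME assay on MDCK cells (Canis lupus familiaris) for cytotoxicity, read by microscopy, with a stated time of 48 h (on this read-out higher numbers stand for lower toxicity in this test and lower numbers for higher toxicity in this test), compound 3 gives the lowest of the three numbers, the strongest cytotoxicity seen here. Both of its steps lie beyond the scatter: the nearer one is a 16-fold lower number from compound 1 to compound 3 (1.20 log units; beyond the scatter), the further one is a 32-fold lower number from compound 2 to compound 3 (1.51 log units; beyond the scatter). Compound 4 `C[C@H]1[C@H](NCc2cc(C3CCCC3)cs2)C[C@H]2C[C@@H]1C2(C)C` has not yet been measured; its change from compound 3 is cyclopentyl in place of cyclohexyl on an aromatic carbon. Among the measured compounds shown here, no measured step swaps one non-aromatic ring of carbon only for a smaller one of the same kind, but the two steps of a 16-fold lower number from compound 1 to compound 3 (1.20 log units; beyond the scatter) and a 32-fold lower number from compound 2 to compound 3 (1.51 log units; beyond the scatter) show that a cyclohexyl at this place went with a much lower number than a methyl or a thiophen-3-yl. A cyclopentyl keeps a non-aromatic ring of carbon only at that place. The step expected is therefore modest, toward a somewhat higher number: a 1.9-fold higher number from compound 3 to compound 4 (0.28 log units; within the scatter). Compound 4 is estimated at 1500 nM, with a range from 600 nM to 4000 nM.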

Compound 4, minimum cytotoxic concentration: 1560 nM
The estimate for compound 4 lay 1.0-fold (0.02 log units) below the measured number; low and high end bracket the measured number.
By their numbers in this assay, from the lowest: compounds 3 and 4 (each within the scatter of the next); then compounds 1 and 2 (each within the scatter of the next).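

Placing cyclopentyl instead of cyclohexyl on this aromatic carbon gives a 2.0-fold higher number from compound 3 to compound 4 (0.30 log units; within the scatter) in this assay, so the two rings cannot be told apart here. The low number is therefore not tied to cyclohexyl alone, as a non-aromatic ring of carbon only with one carbon fewer still stands well apart from thiophen-3-yl, with a 16-fold lower number from compound 2 to compound 4 (1.20 log units; beyond the scatter), and from methyl, with an 8.0-fold lower number from compound 1 to compound 4 (0.90 log units; beyond the scatter). Nothing shown explains why these two rings go with the lower numbers.

The compounds shown leave open whether the ring itself matters, as a longer open chain such as butyl might tell. They also leave open how a smaller cyclopropyl, or a ring holding an amine nitrogen such as piperidine, would behave at this place.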